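The source may hold more compounds than are shown below. What is called first, only, known or untested is meant among the compounds shown, and "the series" means these compounds.

Measured in an assay on isolated protein for displacement of a labelled ligand from metabotropic glutamate receptor 5 (Homo sapiens), with a stated time of 60 min, tested at 1 uM; a higher number here means more inhibition at the concentration tested (going by the name of the read-out), a lower number less inhibition:
compound 1 `Cc1ccc(S(=O)(=O)c2cnc3ccc(F)cc3c2N2CCC(C)CC2)cc1` gives 91%
compound 2 `Cc1ccc(S(=O)(=O)c2cnc3ccc(F)cc3c2N2CCC(C)CC2)cc1C` gives 92%
compound 3 `COc1ccc(S(=O)(=O)c2cnc3ccc(F)cc3c2N2CCC(C)CC2)cc1Cl` gives 82%

Compound 3 stands at the lower edge of these three numbers, but the gaps are small: a number 9 percentage points lower from compound 1 to compound 3 (within the scatter) and a number 10 percentage points lower from compound 2 to compound 3 (within the scatter), so the three compounds cannot be told apart on this read-out. For the measured compounds named here, the one change that keeps the aromatic ring on the sulfonyl sulfur and adds only a methyl, a number 1 percentage points higher from compound 1 to compound 2 (within the scatter), was likewise flat.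

Compound 4 `COc1cccc(S(=O)(=O)c2cnc3ccc(F)cc3c2N2CCC(C)CC2)c1` is the next compound. Its difference from compound 3: 3-methoxyphenyl in place of 3-chloro-4-methoxyphenyl on a sulfonyl sulfur. Going by the values given here, the steps that bear on it are the two that already exchanged the group on the sulfonyl sulfur, from compound 1 and from compound 2 to compound 3, both within the scatter. Among the compounds with values here, no measured pair removes a chlorine or shifts a methoxy on that ring, so the size of such an effect is unknown from these data, but every change so far on that sulfonyl substituent has left the inhibition essentially where it was.

Compound 4 is therefore expected to show a step of about a number 3 percentage points higher from compound 3 to compound 4 (within the scatter), that is none beyond the scatter. The estimate for compound 4 in this assay is 85%, with a range from 70% to 95%.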

Compound 4, a percentage reported as inhibition, at one concentration (the size of the read-out at that concentration, not a potency): 90%
For compound 4 the middle estimate is 5 percentage points below the measured one, within the range that was stated.
By their numbers in this assay, from the lowest: compounds 3, 4, 1 and 2 (each within the scatter of the next).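

In this assay, 3-methoxyphenyl in place of 3-chloro-4-methoxyphenyl on a sulfonyl sulfur gave a step within the scatter (a number 8 percentage points higher from compound 3 to compound 4 (within the scatter)), so this ring, which carries no chlorine, cannot be told apart from the chlorine-bearing ring on this read-out. Measured against the methyl-bearing rings, 3-methoxyphenyl is equally inseparable from 3,4-dimethylphenyl (a number 2 percentage points lower from compound 2 to compound 4 (within the scatter)) and from 4-methylphenyl (a number 1 percentage points lower from compound 1 to compound 4 (within the scatter)), which extends the flat picture at this position to all four aryl groups shown. Nothing available here accounts for why these exchanges leave the read-out unmoved.

It remains open whether the sulfonyl sulfur would accept a very different group in this place, such as a cyclohexyl ring, a pyridine ring, or a phenyl ring bearing an amine or a carboxylic acid, since every group shown so far is a substituted phenyl ring. Also open, as far as these compounds go, is how these compounds rank in potency, as a percentage at a single concentration does not give one.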